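A few compounds are considered here, and "the series" means these few. Any claim that something is new, unique, unknown or untested is made for them only; others in the source may bear on it.

Compound 1 `CCCCCSc1nc(C(F)(F)F)ccc1CNC(=O)C(C)c1ccc(NS(C)(=O)=O)c(F)c1` sits second highest of the three numbers measured in an assay on CHO-K1 cells for antagonist activity at transient receptor potential cation channel subfamily V member 1 (Homo sapiens), read by FLIPR (a higher number here means a weaker inhibitor, a lower number a stronger inhibitor), where compound 1 gives 2.5 nM. Its nearest neighbour is compound 2 `CC(C(=O)NCc1ccc(C(F)(F)F)nc1SCCOc1ccccc1)c1ccc(NS(C)(=O)=O)c(F)c1`, which in this assay gives 2.3 nM; the step of a 1.1-fold lower number from compound 1 to compound 2 (0.04 log units; within the scatter) is within the scatter. Compound 3 `CC(C(=O)NCc1ccc(C(F)(F)F)nc1SCCCN1CCCCC1)c1ccc(NS(C)(=O)=O)c(F)c1` gives 3 nM, and the step of a 1.2-fold higher number from compound 1 to compound 3 (0.08 log units; within the scatter) is also within the scatter, as is the step between the other two, a 1.3-fold higher number from compound 2 to compound 3 (0.12 log units; within the scatter).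

Compound 4 `CC(C(=O)NCc1ccc(C(F)(F)F)nc1SCCC(=O)O)c1ccc(NS(C)(=O)=O)c(F)c1` differs from compound 1 as follows: carboxy in place of propyl on a saturated chain carbon, two bonds along the chain from a sulfur. Both measured steps from compound 1 exchange the end of the same chain, the step of a 1.1-fold lower number from compound 1 to compound 2 (0.04 log units; within the scatter) bringing in phenoxy and the step of a 1.2-fold higher number from compound 1 to compound 3 (0.08 log units; within the scatter) bringing in piperidin-1-yl, and neither moved the number beyond the scatter. Neither of them, however, brings in a hydrogen-bond donor, so the carboxy change is not directly sampled. On that basis the expected step is a 2.4-fold higher number from compound 1 to compound 4 (0.38 log units; beyond the scatter), a number somewhat higher than compound 1 but with wide uncertainty. Compound 4 is therefore estimated to give 6 nM in this assay, within a range from 1.5 nM to 40 nM.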

Compound 4, inhibition constant: "not active" (no number reported)
Nothing numeric was reported for compound 4; the estimate stays without a comparison.
By their numbers in this assay, from the lowest: compounds 2, 1 and 3 (each within the scatter of the next).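

In this assay, within the data shown here, compound 4 was reported as not active, without a number, so no step to compound 1, 2 or 3 can be read. No measurement shown bears on the reason for this result. The compounds shown leave open whether the carboxy end itself or something else about the 2-carboxyethyl chain sets compound 4 apart.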